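The source may report more compounds than this note shows. Statements on the series, on what has been measured and on what is new or still open speak of the compounds shown alone.

Three compounds of the series have numbers in a functional assay on MCF7 cells (Homo sapiens) for antiproliferative activity, read by MTT assay, with a stated time of 72 h; on this read-out higher numbers stand for weaker inhibition and lower numbers for stronger inhibition. Compound 1 `O=C1O[C@H]([C@@H](O)Cn2cc(CNS(=O)(=O)c3ccc(F)cc3)nn2)C(OCc2ccccc2)=C1OCc1ccccc1` gives 26800 nM. Compound 2 `O=C1O[C@H]([C@@H](O)Cn2cc(-c3cc(F)cc(F)c3)nn2)C(OCc2ccccc2)=C1OCc1ccccc1` gives 27700 nM. Compound 3 `C[Si](C)(C)c1cn(C[C@H](O)[C@H]2OC(=O)C(OCc3ccccc3)=C2OCc2ccccc2)nn1` gives 12100 nM, the lowest of the three numbers, with its steps to both other compounds beyond the scatter; compound 1 and compound 2, by contrast, differ by a 1.0-fold higher number from compound 1 to compound 2 (0.01 log units; within the scatter). The measured steps onto compound 3 are a 2.2-fold lower number from compound 1 to compound 3 (0.35 log units; beyond the scatter) and a 2.3-fold lower number from compound 2 to compound 3 (0.36 log units; beyond the scatter), both modest.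

Compound 4 `Cc1ccc(S(=O)(=O)NCc2cn(C[C@H](O)[C@H]3OC(=O)C(OCc4ccccc4)=C3OCc3ccccc3)nn2)cc1` has not been measured. It differs from compound 3 by a group of 12 heavy atoms (8 carbon, 1 nitrogen, 2 oxygen, 1 sulfur; one six-membered aromatic ring of carbon only) in place of a group of 4 heavy atoms (3 carbon, 1 silicon; no ring), on an aromatic carbon. This change runs opposite to the step from compound 1 to compound 3, and the entering group of compound 4 differs from the group of compound 1 only as 4-methylphenyl differs from 4-fluorophenyl. The step from compound 1 to compound 3 was a 2.2-fold lower number from compound 1 to compound 3 (0.35 log units; beyond the scatter), so a step of about that size back to a higher number is expected here. Compound 4 is therefore estimated to give 26000 nM in this assay, with a range of 12000 nM to 55000 nM. The expected step is a 2.1-fold higher number from compound 3 to compound 4 (0.33 log units; beyond the scatter).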

Compound 4, half-maximal inhibitory concentration: 6400 nM
Beside the measured number, compound 4's estimate is 4.1-fold (0.61 log units) above it; the whole stated range lies above it.
By their numbers in this assay, from the lowest: compounds 4 and 3 (each within the scatter of the next); then compounds 1 and 2 (each within the scatter of the next).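

In this assay, the (((4-methylphenyl)sulfonyl)amino)methyl group shows that a group of this size on this aromatic carbon of the five-membered ring does not by itself give a higher number: a 1.9-fold lower number from compound 3 to compound 4 (0.28 log units; within the scatter) stays within the scatter, unlike the step onto compound 3 from compound 1. The 4-substituent on the phenyl ring now matters as well, since methyl in place of fluoro gives a 4.2-fold lower number from compound 1 to compound 4 (0.62 log units; beyond the scatter) and so separates two otherwise identical groups, while a 4.3-fold lower number from compound 2 to compound 4 (0.64 log units; beyond the scatter) also sets the new group apart from 3,5-difluorophenyl. No supporting data bear on why this exchange shifts the number.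

Open, on these data alone, is whether chloro, methoxy or an amine in place of that methyl would follow the same direction. Also open, as far as these compounds go, is whether the sulfonyl amino link is needed, for instance with a carboxamide in its place.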